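The compounds below may be only part of what the source reports. "The series", "measured", "known", "first", "only" and "open" are said of these compounds alone.

Measured so far in an assay on isolated protein for inhibition of Dihydrofolate reductase (Mus musculus); a higher number here means a more potent compound, by a factor of ten per unit of this negative logarithm, a lower number a less potent compound:

compound 1, `CC1(C)N=C(N)N=C(N)N1c1cccc(CCCCc2ccc(Cl)cc2Cl)c1`, gives 8.03
compound 2, `CC1(C)N=C(N)N=C(N)N1c1cccc(CCCCc2cccc(S(=O)(=O)F)c2)c1`, gives 8.1
compound 3, `CC1(C)N=C(N)N=C(N)N1c1cccc(CCCCc2ccccc2)c1`, gives 8.35

Compound 2 sits in the middle of the three numbers: compound 1 lies a number 0.07 log units higher from compound 1 to compound 2 (within the scatter), and compound 3 lies a number 0.25 log units higher from compound 2 to compound 3 (within the scatter), both within the scatter, so these three are not really separated. Compound 4, `CC1(C)N=C(N)N=C(N)N1c1cccc(CCCCc2ccc(Cl)c(S(=O)(=O)F)c2)c1`, differs from compound 2 by chloro in place of hydrogen on an aromatic carbon. Among the measured compounds shown here, three steps bear on this. Swapping the 2,4-dichlorophenyl of compound 1 for the plain phenyl of compound 3 gives a number 0.32 log units higher from compound 1 to compound 3 (beyond the scatter), a modest gain; removing the fluorosulfonyl of compound 2 gives a number 0.25 log units higher from compound 2 to compound 3 (within the scatter); and exchanging two chlorines for one fluorosulfonyl gives a number 0.07 log units higher from compound 1 to compound 2 (within the scatter). Putting a chlorine back onto the ring therefore points, if anywhere, slightly downward, but nothing here exceeds the scatter. The expected step from compound 2 is a number 0.10 log units lower from compound 2 to compound 4 (within the scatter), no more than the scatter. Compound 4 is thus estimated at 8, within 7.6 to 8.4.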

Compound 4, logarithm of the reciprocal of the active concentration, log(1/C): 8.37
Beside the measured number, compound 4's estimate is 0.37 log units below it; low and high end bracket the measured number.
By their numbers in this assay, from the lowest: compounds 1, 2, 3 and 4 (each within the scatter of the next, the first and the last beyond it).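

In this assay, placing a chloro ortho to the fluorosulfonyl group and para to a large group gives a number 0.27 log units higher from compound 2 to compound 4 (within the scatter), so compound 2 and compound 4 are not separated and this position tolerates the added chlorine with no loss that can be detected. The earlier compounds shown here showed chlorine only within the 2,4-dichlorophenyl group, where two chlorines were exchanged together, whereas this step isolates a single chloro at one place on the ring. Nothing available here accounts for this result.

Going by these compounds, it remains open whether chloro would give the same outcome on the plain phenyl ring of compound 3, where no fluorosulfonyl group is present. On these data alone, it is also open whether a bromo, a methyl or an amine at this position would stay as close to compound 2.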